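This account rests on a few compounds, and the source may have more. Where it says the series, first, only, none or still open, it means among the compounds named here.

In a functional assay on KYSE-450 cells (Homo sapiens) for inhibition, read by CCK-8 assay, with a stated time of 48 h (a higher number here means a weaker inhibitor, a lower number a stronger inhibitor), compound 1 `CCN1CCN(C(=S)SCC(=O)N(Cc2ccc(OC)cc2)c2cc(OC)c(OC)c(OC)c2)CC1` gives 3070 nM, and compound 2 `COc1ccc(CN(C(=O)CSC(=S)N2CCc3ccccc32)c2cc(OC)c(OC)c(OC)c2)cc1` gives 6940 nM. For compound 3 `COc1ccc(CN(C(=O)CSC(=S)N2CCc3cc(Br)ccc32)c2cc(OC)c(OC)c(OC)c2)cc1` the assay reports only a limit, > 20000 nM. Compound 4 `COc1ccc(CN(C(=O)CSC(=S)N2CCc3ccccc3C2)c2cc(OC)c(OC)c(OC)c2)cc1` differs from compound 3 on a thiocarbonyl carbon, with 1,2,3,4-tetrahydroisoquinolin-2-yl in place of 5-bromo-2,3-dihydro-1H-indol-1-yl (1,2,3,4-tetrahydroisoquinolin-2-yl in place of 5-bromo-2,3-dihydro-1H-indol-1-yl on a thiocarbonyl carbon). Two measured changes bear on this. Bromo in place of hydrogen gave an at least 2.8-fold higher number from compound 2 to compound 3 (0.45 log units; beyond the scatter), and exchanging the group on the thiocarbonyl carbon gave a 2.3-fold higher number from compound 1 to compound 2 (0.35 log units; beyond the scatter). Compound 4 has no bromo, so a return towards compound 2 at 6940 nM is expected. The expected change is an at least 3.3-fold lower number from compound 3 to compound 4 (0.52 log units; beyond the scatter), towards a lower number and so a stronger inhibitor. Compound 4 is estimated at 6000 nM, within an expected range of 2200 nM to 16000 nM.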

Compound 4, half-maximal inhibitory concentration: > 20000 nM
Compound 4: a limit, no number; the forecaster's own chance of this, stated with the estimate: 15%; middle value at least 3.3-fold (0.52 log units) away from the limit.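

In this assay compound 4 carries no bromo and still reports only a limit, > 20000 nM. On the thiocarbonyl carbon, then, the loss is not tied to bromo alone: 1,2,3,4-tetrahydroisoquinolin-2-yl gives an at least 2.8-fold higher number from compound 2 to compound 4 (0.45 log units; beyond the scatter) and an at least 6.5-fold higher number from compound 1 to compound 4 (0.81 log units; beyond the scatter), while the step from compound 3 to compound 4 cannot be read. The comparison of these two compounds stops at the assay's ceiling: the limit of > 20000 nM in this assay, at which 2 of the 4 values shown sit.

Still open, from the compounds shown here alone, is whether a morpholine, or a piperazine bearing a longer chain than ethyl, on the thiocarbonyl carbon would match compound 1 at 3070 nM.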